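Triazole sulfanyl series: aryl in place of butyl

The source may hold more compounds than are shown below. What is called first, only, known or untested is meant among the compounds shown, and "the series" means these compounds.

Two compounds carry numbers in a functional assay on the whole organism (strain Wistar) for inhibition, with Rattus norvegicus as the target, read by paw edema, with a stated time of 4 h, at a dose of 10 mg/kg by the oral route; on this read-out higher numbers stand for more inhibition at the one dose given (going by the name of the read-out) and lower numbers for less inhibition. Compound 1 `c1ccc(-c2ccc(OCc3nnc(-c4ccccc4)o3)cc2)cc1` gives 18.2% in this assay. Compound 2 `CCCCn1c(S)nnc1COc1ccc(-c2ccccc2)cc1` gives 81.8% in this assay, the higher of the two numbers, standing above compound 1 by a gap beyond the scatter. Compound 3 `Fc1ccc(-n2c(S)nnc2COc2ccc(-c3ccccc3)cc2)cc1` is not yet measured. It differs from compound 2 in one place: 4-fluorophenyl in place of butyl on an aromatic nitrogen. The sulfanyl group of compound 2 is kept. Going by the values given here, no step between measured compounds covers a change of this kind, so the size of the effect is open. The expectation rests on compound 2 alone, whose value of 81.8% in this assay sets the starting point. A moderate step downward in this assay, still beyond the scatter, is expected, as a number 19.8 percentage points lower from compound 2 to compound 3 (beyond the scatter). For compound 3 the estimate in this assay is 62%, with a range from 38% to 82%.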

Compound 3, a percentage reported as inhibition, in the whole organism at one dose (the size of the read-out at that dose, not a potency): 79.5%
The estimate for compound 3 lay 17.5 percentage points below the measured number, within the range that was stated.
By their numbers in this assay, from the lowest: compound 1; then compounds 3 and 2 (each within the scatter of the next).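

With the sulfanyl group kept, 4-fluorophenyl in place of butyl on the aromatic nitrogen gives, in this assay, a number 2.3 percentage points lower from compound 2 to compound 3 (within the scatter) and so leaves the read-out at the one dose unchanged within the scatter. Compound 2 alone showed only an open chain at this position; the pair shows that a six-membered aromatic ring can stand there as well, and that high inhibition at this dose does not depend on butyl. This holds for these two groups only, and no measurement is at hand that could explain the match.

The compounds shown leave open whether a shorter chain such as methyl, unsubstituted phenyl, or a phenyl carrying an amine or a carboxylic acid would hold the same level on this nitrogen. Also open, on these data alone, is what a hydroxyl or a methyl in place of the sulfanyl group would do with either butyl or 4-fluorophenyl on the nitrogen.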